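Saturating and methylating the hydantoin of compound 1

This account rests on a few compounds, and the source may have more. Where it says the series, first, only, none or still open, it means among the compounds named here.

compound 1 `CC(C)C(/C=C1\NC(=O)NC1=O)c1ccc(-c2ccc3cccc(F)c3c2)[nH]c1=O`: 43 nM
compound 2 `CCc1cccc2ccc(-c3ccc(C(/C=C4\OC(=O)NC4=O)(CC)CC)c(=O)[nH]3)cc12`: 17 nM

In an assay on membranes from Chem-1 cells for displacement of a labelled ligand from prostaglandin E2 receptor EP3 subtype (Homo sapiens), read by scintillation counting, with a stated time of 2 h (on this read-out higher numbers stand for weaker inhibition and lower numbers for stronger inhibition), compound 1 gives 43 nM, the higher of the two numbers shown. Compound 2 gives 17 nM, and the gap between the two lies beyond the usual scatter. Compound 3 `CC(C)C(CC1C(=O)NC(=O)N1C)c1ccc(-c2ccc3cccc(F)c3c2)[nH]c1=O` differs from compound 1 by a group of 9 heavy atoms (5 carbon, 2 nitrogen, 2 oxygen; one five-membered non-aromatic ring with 2 hetero atoms) in place of a group of 8 heavy atoms (4 carbon, 2 nitrogen, 2 oxygen; one five-membered non-aromatic ring with 2 hetero atoms), on a saturated chain carbon bound to an aromatic carbon and a saturated chain carbon. Among the compounds with values here, no measured pair shows this change, so the direction rests on the structural change alone. Compound 3 is expected to give a weaker result, with a step of an 8.1-fold higher number from compound 1 to compound 3 (0.91 log units; beyond the scatter) beyond the scatter. Compound 3 is estimated at 350 nM, within a range from 60 nM to 2500 nM.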

Compound 3, inhibition constant: 17 nM
The estimate for compound 3 lay 21-fold (1.31 log units) above the measured number, outside the stated range (below it).
By their numbers in this assay, from the lowest: compounds 2 and 3 (each within the scatter of the next); then compound 1.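

In this assay, replacing the group on this saturated chain carbon with (3-methyl-2,5-dioxoimidazolidin-4-yl)methyl gives a 2.5-fold lower number from compound 1 to compound 3 (0.40 log units; beyond the scatter). The position therefore tolerates this change: the entering group has 2 double bonds outside aromatic rings and 1 hydrogen-bond donor, against 3 and 2 in the group that leaves, and the number still falls. Nothing available bears on why it falls. Saturation and the added methyl arrive together in this single step, and the compounds shown do not separate them. They also leave open how a carboxylic acid or an amine would read at this place.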